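A few compounds are considered here, and "the series" means these few. Any claim that something is new, unique, unknown or untested is made for them only; others in the source may bear on it.

Measured so far in an ADME assay on Vero 76 cells (Chlorocebus sabaeus) for cytotoxicity, read by MTT assay, with a stated time of 96 h; a higher number here means that more compound is tolerated, a lower number that less compound is tolerated:

- compound 1 `Cc1ccc(-c2nn(-c3ccccc3)cc2CNc2ccccc2)cc1`: 52000 nM
- compound 2 `Cc1ccc(-c2nn(-c3ccccc3)cc2CNc2ccc(C(F)(F)F)cc2)cc1`: 45000 nM

Going by the values given here, compound 2 is one of only two compounds with a number in this assay, and its nearest neighbour is compound 1, the pair being linked by a 1.2-fold lower number from compound 1 to compound 2 (0.06 log units; within the scatter); the two values therefore sit within the scatter of each other and give no separation.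

Compound 3 `FC(F)(F)c1ccc(NCc2cn(-c3ccccc3)nc2-c2ccccc2)cc1` is the next compound to be measured. Relative to compound 2 the change is hydrogen in place of methyl on an aromatic carbon. Among the compounds with values here, neither measured step bears directly on this change: the single step known, a 1.2-fold lower number from compound 1 to compound 2 (0.06 log units; within the scatter), concerns a different substituent on the other aromatic ring and was itself within the scatter. Within the data shown here, with no relevant precedent, the expectation is that removing the methyl leaves the tolerated concentration essentially unchanged, so a step of no change at the digits printed from compound 2 to compound 3 (within the scatter) is expected rather than any movement beyond the scatter. Compound 3 is thus estimated at 45000 nM, with a range from 20000 nM to 100000 nM.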

Compound 3, half-maximal cytotoxic concentration: 17000 nM
Beside the measured number, compound 3's estimate is 2.6-fold (0.42 log units) above it, and the stated range ends above it.
By their numbers in this assay, from the lowest: compound 3; then compounds 2 and 1 (each within the scatter of the next).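

In this assay, going by these compounds alone, 4-methylphenyl to phenyl is the first change to move the number beyond the scatter: a 2.6-fold lower number from compound 2 to compound 3 (0.42 log units; beyond the scatter). This position, on an aromatic carbon para to a large group, therefore responds to the loss of methyl, with less compound tolerated, whereas trifluoromethyl in place of hydrogen gave only a 1.2-fold lower number from compound 1 to compound 2 (0.06 log units; within the scatter), which lies within the scatter. No measurement at hand accounts for the shift.

As far as these compounds go, the methyl-to-hydrogen change is seen in a single pair, so it remains open whether the same step holds without trifluoromethyl in the molecule. Also open, from the compounds shown here alone, is how a methoxy group, a chlorine or an amine at this position would read in this assay.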